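This account rests on a few compounds, and the source may have more. Where it says the series, first, only, none or still open, it means among the compounds named here.

Of the compounds shown here, two with a shared urea core have been measured so far. Compound 1 `O=C(NCc1ccc(S(=O)(=O)c2ccccc2)cc1)N1Cc2cccnc2C1` gives 144000 nM in a physicochemical assay for solubility, in phosphate buffer, with a stated time of 24 h, at pH 7.4, tested at 100 uM; on this read-out lower numbers stand for lower solubility and higher numbers for higher solubility. Compound 2 `O=C(NCc1ccc(S(=O)(=O)c2cc(F)cc(F)c2)cc1)N1Cc2ccncc2C1` gives 16000 nM in this assay, which is the lower of the two numbers; the gap between compound 1 and compound 2 lies beyond the usual scatter of repeated runs. Compound 3 `O=C(NCc1ccc(S(=O)(=O)C2CCN(C3COC3)CC2)cc1)N1Cc2ccncc2C1` has not yet been measured. It differs from compound 2 in one place: 1-(oxetan-3-yl)piperidin-4-yl in place of 3,5-difluorophenyl on a sulfonyl sulfur. Within the data shown here, no measured pair shows this exact change, so no measured step can be quoted for it. Compound 3 is nonetheless expected to move upward, with an estimated step of a 7.5-fold higher number from compound 2 to compound 3 (0.88 log units; beyond the scatter) in this assay. In line with that, compound 3 is estimated to give 120000 nM, with a range from 40000 nM to 200000 nM.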

Compound 3, solubility: 121000 nM
For compound 3 the middle estimate is 1.0-fold (0.00 log units) below the measured one, within the range that was stated.
By their numbers in this assay, from the lowest: compound 2; then compounds 3 and 1 (each within the scatter of the next).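

The sulfonyl sulfur proves to be a place where the group attached can clearly change the read-out: in this assay the swap gives a 7.6-fold higher number from compound 2 to compound 3 (0.88 log units; beyond the scatter) on an otherwise unchanged molecule. The change removes a six-membered aromatic ring of carbon only and brings in two non-aromatic rings, each with 1 hetero atom, along with 2 hydrogen-bond acceptors. No measurement here explains which of these differences matters, so the step belongs to the whole group swap and to no single part of it.

As far as these compounds go, whether the oxetan-3-yl part is needed stays open, since a plain piperidin-4-yl in this place could be compared directly with compound 3. A cyclohexyl on the sulfonyl sulfur would likewise help to separate the effect of the ring nitrogen from that of losing the aromatic ring.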